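A few compounds are considered here, and "the series" means these few. Any claim that something is new, unique, unknown or untested is made for them only; others in the source may bear on it.

Two compounds of the series have been run in an ADME assay on HepG2 cells (Homo sapiens) for cytotoxicity, read by luminescence, CellTiter-Glo and ATP content, with a stated time of 72 h; on this read-out lower numbers stand for an effect already at smaller amounts and higher numbers for an effect only at larger amounts of compound. Compound 1 `Fc1ccc(Cc2ccc3c(NCCCNCc4ccco4)ccnc3c2)c(Cl)c1` gives 5730 nM; compound 2 `COc1cccc(CNCCCNc2ccnc3cc(-c4ccccc4)ccc23)c1O` gives 3210 nM. Compound 2 stands at the lower of the two numbers, but the gap to compound 1 lies within the scatter, so the two read as alike on this read-out. Compound 3 `COc1cccc(CNCCCNc2ccnc3cc(Cc4ccc(F)cc4Cl)ccc23)c1O` has not yet been measured in this assay. It differs from compound 2 in one place: 2-chloro-4-fluorobenzyl in place of phenyl on an aromatic carbon. The same 2-chloro-4-fluorobenzyl is carried by compound 1, whose 5730 nM sits close to the number of compound 2, so no step beyond the scatter is expected from compound 2 to compound 3 in this assay, in either direction. The step of a 1.2-fold higher number from compound 2 to compound 3 (0.10 log units; within the scatter) is accordingly expected to be small. For compound 3 the estimate is 4000 nM, with a range from 1500 nM to 10000 nM.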

Compound 3, half-maximal effective concentration: 2350 nM
The estimate for compound 3 lay 1.7-fold (0.23 log units) above the measured number; measured number inside the range.
By their numbers in this assay, from the lowest: compounds 3, 2 and 1 (each within the scatter of the next, the first and the last beyond it).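

In this assay, 2-chloro-4-fluorobenzyl in place of phenyl on the aromatic carbon gives a 1.4-fold lower number from compound 2 to compound 3 (0.14 log units; within the scatter) and thus, with the rest of the structure held, no change beyond the scatter at this position. With 2-chloro-4-fluorobenzyl held, 2-hydroxy-3-methoxyphenyl in place of furan-2-yl on the saturated chain carbon bound to an amine nitrogen gives a 2.4-fold lower number from compound 1 to compound 3 (0.39 log units; beyond the scatter) and is the one modest step shown in the series, a separation of the two places that the earlier pair, differing in both, could not offer. No measurement at hand accounts for either step.

Going by these compounds, whether the furan-2-yl exchange gives a similar step with phenyl on the aromatic carbon remains open, as this rests on a single pair. Also open, on these data alone, is how a carboxylic acid or an amine on that aromatic carbon, or a longer chain in the saturated linker, would read out in this assay.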